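Outer-ring replacement by bromo in the cyano-pyridine amide series

This account rests on a few compounds, and the source may have more. Where it says the series, first, only, none or still open, it means among the compounds named here.

Measured so far:
compound 1 `CC[C@@H](Nc1c(C#N)c(-c2ccc(-c3cccc(C)c3)cc2)nc2cnccc12)C(N)=O` — 3
compound 2 `CC[C@@H](Nc1c(C#N)c(-c2ccc(-c3ccncc3C)cc2)nc2cnccc12)C(N)=O` — 2
compound 3 `CC[C@@H](Nc1c(C#N)c(-c2ccc(-c3cccc(CO)c3)cc2)nc2cnccc12)C(N)=O` — 2

In a physicochemical assay for lipophilicity, read by HPLC, at pH 7.5 (on this read-out higher numbers stand for higher lipophilicity and lower numbers for lower lipophilicity), compound 3 stands level with compound 2 at the digits shown, the two together the lowest of the three numbers, with no change at the digits printed from compound 2 to compound 3 (within the scatter). Compound 1 sits higher, by a number 1.00 log units lower from compound 1 to compound 3 (beyond the scatter) and a number 1.00 log units lower from compound 1 to compound 2 (beyond the scatter).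

Compound 4 `CC[C@@H](Nc1c(C#N)c(-c2ccc(Br)cc2)nc2cnccc12)C(N)=O` differs from compound 3 by bromo in place of 3-(hydroxymethyl)phenyl on an aromatic carbon. Going by the values given here, no measured step swaps the whole outer ring for a single atom; the two steps that touched that ring each moved this assay by about one unit. The removal of the hydroxy-bearing ring and the entry of bromo are expected to roughly offset, so for compound 4 a step of no change at the digits printed from compound 3 to compound 4 (within the scatter) is estimated, within the scatter. Compound 4 is expected at 2, between 1.3 and 2.8.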

Compound 4, distribution coefficient: 2.2
Compound 4: the middle estimate sits 0.20 log units below what was measured; measured number inside the range.
By their numbers in this assay, from the lowest: compounds 2, 3 and 4 (each within the scatter of the next); then compound 1.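

In this assay, a single bromo on an aromatic carbon, para to a large group, takes the place of a whole outer ring and reads with a step of a number 0.20 log units higher from compound 3 to compound 4 (within the scatter) and one of a number 0.20 log units higher from compound 2 to compound 4 (within the scatter), yet gives a number 0.80 log units lower from compound 1 to compound 4 (beyond the scatter). At this position, then, an outer ring is not required to reach the level of compound 2 and compound 3, and only the 3-methylphenyl ring of compound 1 stands apart. Nothing available accounts for this.

As far as these compounds go, whether chloro, an amine or a carboxylic acid at this place would read at the same level remains open.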